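Methyl on a saturated ring carbon: cytotoxicity note

A few compounds are considered here, and "the series" means these few. Any claim that something is new, unique, unknown or untested is made for them only; others in the source may bear on it.

Compound 1 `CO/N=C(\C)CCN1CCN(c2nc(=O)c3cc(C(F)(F)F)cc([N+](=O)[O-])c3s2)CC1` and compound 2 `CON=C1CCC(CN2CCN(c3nc(=O)c4cc(C(F)(F)F)cc([N+](=O)[O-])c4s3)CC2)CC1` share one core and differ only in the group on a saturated chain carbon bound to an amine nitrogen in a ring. In an ADME assay on Vero cells (Chlorocebus sabaeus) for cytotoxicity (on this read-out higher numbers stand for lower toxicity in this test and lower numbers for higher toxicity in this test), compound 1 gives only a limit of the assay, > 64 ug/mL. In this assay compound 2 likewise gives only a limit, > 64 ug/mL. The step that the two limits leave unreadable from compound 1 to compound 2 is therefore of unreadable size; both values sit at the limit of > 64 ug/mL in this assay, at which 2 of the 2 values shown sit. Compound 2 thus stands at the limit, with no number that would rank it.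

Compound 3 `CON=C1CCC(CN2CCN(c3nc(=O)c4cc(C(F)(F)F)cc([N+](=O)[O-])c4s3)[C@@H](C)C2)CC1` differs from compound 2 by methyl in place of hydrogen on a saturated ring carbon. Among the measured compounds shown here, the single measured step, from compound 1 to compound 2, is unreadable and concerns another position, so no measured step sizes this change. Given (the limit of > 64 ug/mL in this assay, at which 2 of the 2 values shown sit), where both measured compounds sit, the expectation for compound 3 in this assay is again a limit, a step that the limit leaves unreadable from compound 2 to compound 3 of no readable size. Compound 3 is therefore estimated at 80 ug/mL, within 40 ug/mL to 200 ug/mL.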

Compound 3, half-maximal cytotoxic concentration: > 64 ug/mL
Compound 3 was reported as a limit; the forecaster's own chance of this, stated with the estimate: 85%; the middle value does not contradict the limit.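

Compound 2 and compound 3 are both reported only as limits in this assay, so methyl in place of hydrogen on a saturated ring carbon gives no readable step: the limit of > 64 ug/mL in this assay, at which 3 of the 3 values shown sit.

The compounds shown leave open how compound 1, compound 2 and compound 3 rank against one another in this assay, and whether the methyl changes the read-out at all.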